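Swapping a Four-Membered Ring for a Six-Membered One

The compounds below may be only part of what the source reports. "The series", "measured", "known", "first", "only" and "open" are said of these compounds alone.

Of the compounds shown here, three with the same core have been tested in an assay for inhibition of Tryptophan 2,3-dioxygenase (Homo sapiens), with stated times of 10 min and 60 min, tested at 100 uM; a lower number here means a weaker effect, a higher number a stronger effect of the compound at the concentration tested. Compound 1 `Oc1ccc(CNc2cc(C(F)(F)F)cc3[nH]ncc23)cc1` gives 91%, compound 2 `FC(F)(F)c1cc(NC[C@H]2CCCN2)c2cn[nH]c2c1` gives 84%, and compound 3 `FC(F)(F)c1cc(NCC2CNC2)c2cn[nH]c2c1` gives 49%. Compound 3 stands lowest of the three: its nearest neighbour is compound 2 and its furthest is compound 1, and both gaps lie beyond the scatter of this measurement.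

Compound 4 `FC(F)(F)c1cc(NC[C@@H]2CCCCN2)c2cn[nH]c2c1` differs from compound 3 in one place. piperidin-2-yl in place of azetidin-3-yl on a saturated chain carbon bound to a nitrogen on an aromatic ring

The measured steps that touch the azetidin-3-yl group are large: a number 35 percentage points lower from compound 2 to compound 3 (beyond the scatter) and a number 42 percentage points lower from compound 1 to compound 3 (beyond the scatter). By contrast, a number 7 percentage points lower from compound 1 to compound 2 (within the scatter). Read in reverse, the step from compound 2 to compound 3 shows that moving from azetidin-3-yl to a pyrrolidin-2-yl group is a large gain. Piperidin-2-yl is a saturated ring of the same kind, one member larger, and no measured pair shows what that extra member does on its own. A large rise in this assay is nonetheless the most reasonable expectation, bringing compound 4 close to compound 2.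

Compound 4 is therefore expected to give about 80% in this assay, with a likely range of 60% to 95%. This estimate corresponds to an expected step of a number 31 percentage points higher from compound 3 to compound 4 (beyond the scatter).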

Compound 4, a percentage reported as inhibition, at one concentration (the size of the read-out at that concentration, not a potency): 88%
Compound 4: middle estimate off by 8 percentage points, on the low side; measured number inside the range.
By their numbers in this assay, from the lowest: compound 3; then compounds 2, 4 and 1 (each within the scatter of the next).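

Adding a second larger ring shows that the low result of compound 3 is not shared by saturated nitrogen rings in general: in this assay there is a number 39 percentage points higher from compound 3 to compound 4 (beyond the scatter) when piperidin-2-yl replaces azetidin-3-yl on this saturated chain carbon. One ring member more than pyrrolidin-2-yl makes no difference that can be told apart, with a number 4 percentage points higher from compound 2 to compound 4 (within the scatter) in this comparison, and the same holds against 4-hydroxyphenyl, with a number 3 percentage points lower from compound 1 to compound 4 (within the scatter) here, so among these four compounds only compound 3 stands apart. Nothing available explains why the azetidin-3-yl group gives this gap.

Azetidin-3-yl differs from the two larger rings both in ring size and in the ring carbon that carries the chain, so an azetidin-2-yl group would be needed to separate those two changes. A piperidin-3-yl or piperidin-4-yl group, or the mirror-image form of piperidin-2-yl, would show whether the attachment point or the handedness of the six-membered ring matters, while a reading at a single concentration cannot show whether compound 1, compound 2 and compound 4 would differ in the size of their effect at other concentrations.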